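Propoxy in Place of Isobutylsulfanyl: Expected Cell Tolerance

This account rests on a few compounds, and the source may have more. Where it says the series, first, only, none or still open, it means among the compounds named here.

Three compounds sharing one core have been examined in an ADME assay on MOLT-3 cells (Homo sapiens) for cytotoxicity, with a stated time of 7 days; a higher number here means that more compound is tolerated, a lower number that less compound is tolerated. Compound 1 `CNc1nc(N)nc2c1ncn2/C=C1/CC1(CO)CO` gave only a limit of the assay, > 20000 nM. For compound 2 `CC(C)CSc1nc(N)nc2c1ncn2/C=C1/CC1(CO)CO` the outcome is "not determined" (no result reported), so no number is known for it. Compound 3 `CN(C)c1nc(N)nc2c1ncn2/C=C1/CC1(CO)CO` likewise gave "not determined" (no result reported). Compound 2 therefore stands without any measured figure, beside one companion whose result is a limit and another without a result. Compound 4 `CCCOc1nc(N)nc2c1ncn2/C=C1/CC1(CO)CO` differs from compound 2 in one place: propoxy in place of isobutylsulfanyl on an aromatic carbon. With no measured step among these compounds, no change beyond the usual scatter is anticipated in this assay, neither upward nor downward. The one available anchor is that compound 1 reached only the limit marked by the limit of > 20000 nM in this assay, at which 1 of the 3 values shown sits. Compound 4 is accordingly expected to sit near 20000 nM, in the range 8000 nM to 50000 nM.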

Compound 4, half-maximal cytotoxic concentration: > 20000 nM
Compound 4: a limit, no number; the forecaster's own chance of this, stated with the estimate: 70%; the middle value sits exactly at the limit.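

Compound 1 and compound 4 both gave a limit rather than a number in this assay, so no step between them can be read: the limit of > 20000 nM in this assay, at which 2 of the 4 values shown sit.

As far as these compounds go, how much compound either one truly tolerates, and how compound 4 compares with compound 2, stays open.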